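The compounds below may be only part of what the source reports. "The series", "measured", "known", "first", "only" and "open" are said of these compounds alone.

Within the data shown here, compound 1 `COc1cc2c(Nc3ccc(C#N)cc3)ncnc2cc1OCCCN1CCCCC1` is the only compound with a number in a functional assay on SH-SY5Y cells (Homo sapiens) for antiproliferative activity, read by MTT assay, with a stated time of 72 h (a higher number here means a weaker inhibitor, a lower number a stronger inhibitor), where compound 1 gives 18800 nM. Compound 2 `COc1cc2c(Nc3ccc(C#N)cc3)ncnc2cc1OCCCN1CCC(O)CC1` carries a hydroxy in place of hydrogen on a saturated ring carbon; in this assay compound 2 gives > 100000 nM, a limit of the assay rather than a number. Among the measured compounds shown here, the one measured change at this position, an at least 5.3-fold higher number from compound 1 to compound 2 (0.72 log units; beyond the scatter), sits at the limit of > 100000 nM in this assay, at which 1 of the 2 values shown sits. Compound 3 `COc1cc2c(Nc3ccc(C#N)cc3)ncnc2cc1OCCCN1CCC(N2CCCCC2)CC1` differs from compound 1 by piperidin-1-yl in place of hydrogen on a saturated ring carbon. The same saturated ring carbon is altered, so the step from compound 1 to compound 2 bears on it, though the entering piperidin-1-yl group is not the hydroxy group, and no group of this kind has been measured here. For compound 3 a weaker inhibitor is expected, with a step of a 2.1-fold higher number from compound 1 to compound 3 (0.33 log units; beyond the scatter). Compound 3 is estimated at 40000 nM, between 10000 nM and 150000 nM.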

Compound 3, half-maximal inhibitory concentration: 9810 nM
Compound 3: the middle estimate sits 4.1-fold (0.61 log units) above what was measured; the measured number lies below the stated range.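

At this saturated ring carbon, the change from hydrogen to piperidin-1-yl in this assay stays within the scatter (a 1.9-fold lower number from compound 1 to compound 3 (0.28 log units; within the scatter)), so a whole second ring can stand here with no readable shift. The loss seen with hydroxy therefore does not extend to every group at this carbon, since piperidin-1-yl in place of hydroxy returns a measurable number (an at least 10-fold lower number from compound 2 to compound 3 (1.00 log units; beyond the scatter)). That step is open on one side, as compound 2 gives a limit of the assay and not a number: the limit of > 100000 nM in this assay, at which 1 of the 3 values shown sits.

As far as these compounds go, whether this carbon accepts other groups, such as a dimethylamino group, a morpholin-4-yl ring or a methoxy, stays open. With only hydrogen, hydroxy and piperidin-1-yl shown here, it also remains open whether the nitrogen of the entering ring or its carbons separate compound 3 from compound 2.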